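Cytotoxicity on monocytic cells: amide variation at the shared core

This account rests on a few compounds, and the source may have more. Where it says the series, first, only, none or still open, it means among the compounds named here.

Three compounds of this series have been run in a toxicity assay on THP-1 cells (Homo sapiens) for inhibition; a lower number here means that less compound is tolerated, a higher number that more compound is tolerated. Compound 1 `COc1ccc(-c2cnc(NC(=O)C3CCNCC3)n2C)cc1` carries a piperidin-4-yl group on the amide carbonyl. In this assay compound 1 gives only a limit, > 100000 nM. Compound 2 `Cn1c(-c2ccccc2F)cnc1NC(=O)c1ccc(F)cc1` likewise reaches only the limit, > 100000 nM. Compound 3 `COc1ccc(-c2noc(NC(=O)c3ccc(F)cc3)c2C)cc1`, built on a different ring system, also returns the limit, > 100000 nM. Thus (the limit of > 100000 nM in this assay, at which 3 of the 3 values shown sit); no compound so far has a measured number in this assay, and compound 1 stands level with the other two at that limit.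

Compound 4 `COc1ccc(-c2cnc(NC(=O)c3cccc(C)c3)n2C)cc1` is the next member to be tested. Against compound 1 the change is 3-methylphenyl in place of piperidin-4-yl on a carbonyl carbon; the rest of the molecule is kept. Going by the values given here, with every value so far sitting at the limit, no direction can be read from the series, and the step is expected to show no change beyond the scatter, estimated as a number no higher from compound 1 to compound 4 (the limit leaves the size open). For compound 4 in this assay the expected value is 100000 nM, within a range from 30000 nM to 300000 nM, most likely again reported as a limit rather than a number.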

Compound 4, half-maximal cytotoxic concentration: > 100000 nM
Compound 4 ended at the assay's limit (the forecaster's own chance of this, stated with the estimate: 75%); the middle value sits exactly at the limit.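

Going by these compounds alone, with compound 4, as with compound 1, only a limit is available, so no step between the two can be read: the limit of > 100000 nM in this assay, at which 4 of the 4 values shown sit. The compounds shown leave open whether in this assay any amide on the shared core gives a measured number rather than a limit.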